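Sulfonyl aryl variation and mouse liver microsomal half-life

This account rests on a few compounds, and the source may have more. Where it says the series, first, only, none or still open, it means among the compounds named here.

Measured compounds:
compound 1 `O=C(NCc1ccc(F)cc1)c1ccc(N2CCN(S(=O)(=O)c3cccnc3O)CC2)nn1`: 1.2 h
compound 2 `Cc1cc(F)ccc1S(=O)(=O)N1CCN(c2ccc(C(=O)NCc3ccc(F)cc3)nn2)CC1`: 0.25 h
compound 3 `O=C(NCc1ccc(F)cc1)c1ccc(N2CCN(S(=O)(=O)c3ccccc3C(F)(F)F)CC2)nn1`: 0.517 h

In an ADME assay on microsomes from liver (Mus musculus) for metabolic stability, read by LC-MS, using NADPH, tested at 10 uM (on this read-out higher numbers stand for a longer-lived compound and lower numbers for a shorter-lived compound), compound 1 gives 1.2 h, compound 2 gives 0.25 h and compound 3 gives 0.517 h. Compound 3 stands second highest of the three numbers: a 2.1-fold higher number from compound 2 to compound 3 (0.32 log units; beyond the scatter), whereas a 2.3-fold lower number from compound 1 to compound 3 (0.37 log units; beyond the scatter). All three measured steps, including a 4.8-fold lower number from compound 1 to compound 2 (0.68 log units; beyond the scatter), exchange the whole aryl group on the sulfonyl sulfur.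

Compound 4 `O=C(NCc1ccc(F)cc1)c1ccc(N2CCN(S(=O)(=O)c3ccc(F)cc3C(F)(F)F)CC2)nn1` differs from compound 3 by fluoro in place of hydrogen on an aromatic carbon, so that 2-(trifluoromethyl)phenyl becomes 4-fluoro-2-(trifluoromethyl)phenyl. Among the measured compounds shown here, no measured step isolates a fluoro entering for hydrogen; compound 2 does carry a fluoro on its aryl group and gives the lowest number, but its aryl group differs from that of compound 3 in more than the fluoro. For the measured compounds named here, with no directly comparable step, a change within the scatter in this assay is expected, with direction open. Compound 4 is therefore estimated at 0.5 h, range 0.25 h to 1 h, which means an expected step of a 1.0-fold lower number from compound 3 to compound 4 (0.01 log units; within the scatter).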

Compound 4, half-life: 0.2 h
The estimate for compound 4 lay 2.5-fold (0.40 log units) above the measured number; the whole stated range lies above it.
By their numbers in this assay, from the lowest: compounds 4 and 2 (each within the scatter of the next); then compound 3; then compound 1.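

In this assay, among the compounds shown here, fluoro in place of hydrogen on an aromatic carbon, meta to a trifluoromethyl group and para to a large group, gives a 2.6-fold lower number from compound 3 to compound 4 (0.41 log units; beyond the scatter), the first evidence that a one-atom change on this aryl group can move the half-life beyond the scatter, since every earlier step exchanged the whole group. With that fluoro present, trifluoromethyl in place of methyl gives a 1.3-fold lower number from compound 2 to compound 4 (0.10 log units; within the scatter), which stays within the scatter, while 2-hydroxypyridin-3-yl keeps the highest number of the four, with a 6.0-fold lower number from compound 1 to compound 4 (0.78 log units; beyond the scatter). No measurement at hand accounts for these differences.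

For the compounds shown here, whether the fluoro step carries over to other aryl groups remains open, as only one pair isolates it. Also open, going by these compounds, is how a chloro, a methoxy or an amine at the same place would compare with fluoro.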